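Hydroxy for Methoxy: Working Notes on the Series

A few compounds are considered here, and "the series" means these few. Any claim that something is new, unique, unknown or untested is made for them only; others in the source may bear on it.

compound 1 `Cc1cc(O)cc(-c2nn(CC#N)cc2-c2ccnc(-c3ccc(Oc4ccccc4)cc3)c2)c1` — 7120 nM
compound 2 `COc1cc(C)cc(-c2nn(CC#N)cc2-c2ccnc(-c3ccc(N(C)C)cc3)c2)c1` — > 100000 nM

Two compounds of the shared core carry measurements in a functional assay on Malme-3M cells (Homo sapiens) for inhibition, read by sulforhodamine B assay, with a stated time of 48 h; on this read-out lower numbers stand for higher toxicity in this test and higher numbers for lower toxicity in this test. Compound 1 `Cc1cc(O)cc(-c2nn(CC#N)cc2-c2ccnc(-c3ccc(Oc4ccccc4)cc3)c2)c1` gives 7120 nM. Compound 2 `COc1cc(C)cc(-c2nn(CC#N)cc2-c2ccnc(-c3ccc(N(C)C)cc3)c2)c1` gives only a limit of the assay, > 100000 nM. One of the two values shown sits at that limit (the limit of > 100000 nM in this assay, at which 1 of the 2 values shown sits), so compound 2 stands at the edge of what this assay reports and has no number of its own. Compound 1 and compound 2 differ in two places, so their values are read side by side without a step between them.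

Compound 3 `Cc1cc(O)cc(-c2nn(CC#N)cc2-c2ccnc(-c3ccc(N(C)C)cc3)c2)c1` is not yet measured. From compound 2 it differs by hydrogen in place of methyl on an oxygen on an aromatic ring, which reads as methoxy to hydroxy. Compound 1 carries the same hydroxy group together with a different group elsewhere on the core. No step between measured compounds is shown, so the size of the change from methoxy to hydroxy is not fixed by the data. In this assay the expectation for compound 3 is a modest move toward lower numbers than the limit of compound 2, with wide uncertainty. Compound 3 is expected to give about 60000 nM, within 10000 nM to 300000 nM. The expected step is an at least 1.6-fold lower number from compound 2 to compound 3 (0.22 log units; that floor lies within the scatter).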

Compound 3, concentration lethal to 50% of the cells: > 100000 nM
Compound 3: no number, only a limit (the forecaster's own chance of this, stated with the estimate: 45%); middle value at least 1.6-fold (0.22 log units) from the limit.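

In this assay compound 3 gives only a limit of the assay, > 100000 nM, and not a number. The change from 3-methoxy-5-methylphenyl to 3-hydroxy-5-methylphenyl therefore cannot be sized, as both ends of that step stand at the same edge of the read-out: the limit of > 100000 nM in this assay, at which 2 of the 3 values shown sit.

With the hydroxy group held constant, the series now has its first readable single change: dimethylamino in place of phenoxy on an aromatic carbon gives an at least 14-fold higher number from compound 1 to compound 3 (1.14 log units; beyond the scatter), which leaves compound 1 as the only one of the three with a number of its own.

As far as these compounds go, what the hydroxy group does on its own remains open, since the methoxy to hydroxy change is readable only if both partners give numbers, and with dimethylamino on the core neither does. From the compounds shown here alone, it is also open whether a benzyloxy group or a cyclic amine such as morpholine at that aromatic carbon would give a number in this read-out, or whether the number depends on phenoxy itself.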